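The compounds below may be only part of what the source reports. "The series", "measured", "known", "first", "only" and "open" are said of these compounds alone.

Compound 1 `COc1cc(-c2cc(/C=C/C(=O)c3ccc(N)cc3)[nH]n2)cc(OC)c1OC`: -96%
Compound 2 `COc1ccc(-c2cc(/C=C/C(=O)c3ccc(OC)c(OC)c3)[nH]n2)cc1`: -77%
Compound 3 `COc1cc(-c2cc(/C=C/C(=O)c3ccc(Cl)c(Cl)c3)[nH]n2)cc(OC)c1OC`: -22%

In a functional assay on OVCAR-4 cells (Homo sapiens) for cytotoxicity, read by sulforhodamine B assay, with a stated time of 48 h, tested at 100 uM (on this read-out lower numbers stand for a stronger effect and higher numbers for a weaker effect at the one concentration tested), compound 1 has the lowest number of the three, and so the strongest effect; compound 2 and compound 3 both lie higher, beyond the scatter. Compound 4 `COc1ccc(-c2cc(/C=C/C(=O)c3ccc(N)cc3)[nH]n2)cc1OC` differs from compound 1 by hydrogen in place of methoxy on an aromatic carbon.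

Within the data shown here, the only measured step, a number 74 percentage points higher from compound 1 to compound 3 (beyond the scatter), alters the group on the carbonyl carbon, not the ring that loses the methoxy here, so it does not bear on this change. Among the measured compounds shown here, compound 2, with a single methoxy on that ring but also a different group on the carbonyl side, gives a number above that of compound 1; no single step links the two. For the measured compounds named here, with no directly comparable step, a small step or none beyond the scatter is expected, namely a number 11 percentage points higher from compound 1 to compound 4 (beyond the scatter). Compound 4 is therefore estimated at -85%, within -100% to -55%.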

Compound 4, a percentage reported as activity, at one concentration (the size of the read-out at that concentration, not a potency): -98%
Compound 4: the middle estimate sits 13 percentage points above what was measured; the range from low to high includes it.
By their numbers in this assay, from the lowest: compounds 4 and 1 (each within the scatter of the next); then compound 2; then compound 3.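

Among these compounds, replacing one methoxy with hydrogen gives a number 2 percentage points lower from compound 1 to compound 4 (within the scatter) in this assay, the first step that changes this ring rather than the group on the carbonyl carbon. With the 4-aminophenyl group in place, this methoxy is therefore not needed for the effect at the one concentration tested. No measurement available explains this result.

On these data alone, whether a hydroxyl group or a fluorine atom at this position would read the same remains open. So does whether this swap would behave alike with the 3,4-dichlorophenyl group on the carbonyl carbon.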